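A saturated hydrazide in place of an acrylamide

The source may report more compounds than this note shows. Statements on the series, on what has been measured and on what is new or still open speak of the compounds shown alone.

Of the compounds shown here, three have been measured in a functional assay on A549 cells (Homo sapiens) for inhibition, read by sulforhodamine B assay, with a stated time of 72 h; a lower number here means a stronger inhibitor of growth, a higher number a weaker inhibitor of growth. Compound 1, `Cn1ccc2cc(-c3cnccc3/C=C/C(=O)O)ccc21`, gives only a limit of the assay, > 10000 nM. Compound 2, `CNC(=O)/C=C/c1ccncc1-c1ccc2[nH]ccc2c1`, likewise gives only a limit, > 10000 nM. Among the compounds with values here, compound 3, `CNC(=O)/C=C/c1ccncc1-c1ccc2ccccc2c1`, is the single compound that gives a number, 6620 nM, so it stands alone among the values shown; the other two values are the limit of > 10000 nM in this assay, at which 2 of the 3 values shown sit. Within the data shown here, no step between measured compounds that differ in one place is available, so no measured change can guide the next step.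

Compound 4, `NNC(=O)CCc1ccncc1-c1ccc2ccccc2c1`, differs from compound 3 in one place: 2-(aminocarbamoyl)ethyl in place of 2-(methylcarbamoyl)ethenyl on an aromatic carbon. The ethenyl becomes ethyl and the methylcarbamoyl becomes aminocarbamoyl. Without a measured step to rest on, the step is expected to be modest, leaning toward a weaker inhibitor of growth: a 1.4-fold higher number from compound 3 to compound 4 (0.13 log units; within the scatter). Compound 4 is therefore expected to give about 9000 nM in this assay, in a range from 4000 nM to 30000 nM, with a real chance that only a limit is reported.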

Compound 4, concentration for 50% growth inhibition: > 10000 nM
Compound 4: only a limit was reported; the forecaster's own chance of this, stated with the estimate: 50%; middle value at least 1.1-fold (0.04 log units) from the limit.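

In this assay, 2-(aminocarbamoyl)ethyl in place of 2-(methylcarbamoyl)ethenyl on this aromatic carbon, opposite the ring nitrogen, gives an at least 1.5-fold higher number from compound 3 to compound 4 (0.17 log units; that floor lies within the scatter). Within the data shown here, this is the first step measured at this position, and it yields no number: compound 4 gives > 10000 nM, which is a limit of the assay. The true size of the step therefore cannot be read, and compound 3 remains the only compound in the set with a number rather than a limit: the limit of > 10000 nM in this assay, at which 3 of the 4 values shown sit.

The step joins two changes, ethenyl to ethyl and methylcarbamoyl to aminocarbamoyl, and the compounds shown do not separate them. As far as these compounds go, whether 2-(methylcarbamoyl)ethyl or 2-(aminocarbamoyl)ethenyl at this position would give a number in this assay stays open, as does the outcome with a longer chain.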